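Trifluoromethyl for chloro: expected cytotoxicity of compound 4

The source may report more compounds than this note shows. Statements on the series, on what has been measured and on what is new or still open speak of the compounds shown alone.

In an ADME assay on L6 cells (Rattus norvegicus) for cytotoxicity, read by resazurin assay, with a stated time of 72 h (on this read-out higher numbers stand for weaker inhibition and lower numbers for stronger inhibition), compound 3 `O=C1[C@H]2N=NN(Cc3nc(-c4ccc(Cl)cc4)no3)[C@H]2C(=O)N1c1ccccc1` gives 49.5 ug/mL, the higher of the two plain numbers in the set. Compound 1 `O=C1[C@H]2N=NN(Cc3nc(-c4ccccc4)no3)[C@H]2C(=O)N1c1ccccc1` gives 47.3 ug/mL in this assay, and a 1.0-fold higher number from compound 1 to compound 3 (0.02 log units; within the scatter). Compound 2 `CSc1ccc(-c2noc(CN3N=N[C@@H]4C(=O)N(c5ccccc5)C(=O)[C@@H]43)n2)cc1` gives only a limit in this assay, > 100 ug/mL (the limit of > 100 ug/mL in this assay, at which 1 of the 3 values shown sits). Set against that limit, an at least 2.1-fold higher number from compound 1 to compound 2 (0.32 log units; beyond the scatter), whereas an at least 2.0-fold lower number from compound 2 to compound 3 (0.30 log units; that floor lies within the scatter).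

Compound 4 `O=C1[C@H]2N=NN(Cc3nc(-c4ccc(C(F)(F)F)cc4)no3)[C@H]2C(=O)N1c1ccccc1` differs from compound 3 by trifluoromethyl in place of chloro on an aromatic carbon. Going by the values given here, no measured step exchanges trifluoromethyl for chloro, so the nearest evidence is the set of substituent swaps at that same aromatic carbon: chloro for hydrogen left the number unchanged within the scatter, and methylsulfanyl for hydrogen raised it at least modestly to the limit. The expectation for compound 4 in this assay is therefore a small step, if any, most likely within the scatter, with some chance of a limit rather than a number. Compound 4 is estimated at 55 ug/mL, with a range of 25 ug/mL to 120 ug/mL, which means an expected step of a 1.1-fold higher number from compound 3 to compound 4 (0.05 log units; within the scatter).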

Compound 4, half-maximal inhibitory concentration: 44.4 ug/mL
For compound 4 the middle estimate is 1.2-fold (0.09 log units) above the measured one; measured number inside the range.
By their numbers in this assay, from the lowest: compounds 4, 1 and 3 (each within the scatter of the next). At a limit, above all of these: compound 2.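

In this assay, trifluoromethyl on this aromatic carbon, para to a large group, joins chloro as a swap with no readable effect (in turn a 1.1-fold lower number from compound 3 to compound 4 (0.05 log units; within the scatter) and a 1.1-fold lower number from compound 1 to compound 4 (0.03 log units; within the scatter)). The change from 1 heavy atom in chloro to 4 heavy atoms in trifluoromethyl therefore leaves the read-out within the scatter, so hydrogen, chloro and trifluoromethyl in compounds 1, 3 and 4 form one group, with compound 2 going against it. Compound 2 is separated from compound 4 only by a limit, not a number (with an at least 2.2-fold lower number from compound 2 to compound 4 (0.35 log units; beyond the scatter)), and that separation rests on this entry: the limit of > 100 ug/mL in this assay, at which 1 of the 4 values shown sits.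

Going by these compounds, the true size of the methylsulfanyl effect stays open, as does whether it extends to a longer alkylsulfanyl chain. An amine or a carboxylic acid at this position also remains untested in the compounds shown.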